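The source may report more compounds than this note shows. Statements on the series, on what has been measured and on what is new or still open speak of the compounds shown alone.

Series notes on the amide set sharing the core of compound 1 `COc1ccc(C(=O)Nc2cccc(-c3oc4cc(-c5ccc(F)cc5)ccc4c(=O)c3O)c2)cc1`.

In a functional assay on MCF7 cells (Homo sapiens) for antiproliferative activity, read by CCK-8 assay, with a stated time of 72 h (a lower number here means a stronger inhibitor, a higher number a weaker inhibitor), compound 1 gives 6250 nM. Compound 2 `O=C(Nc1cccc(-c2oc3cc(-c4ccc(F)cc4)ccc3c(=O)c2O)c1)c1cccc(F)c1` gives 5770 nM in this assay, and the change a 1.1-fold lower number from compound 1 to compound 2 (0.03 log units; within the scatter) leaves the two without any separation. Compound 3 `CCc1ccc(C(=O)Nc2cccc(-c3oc4cc(-c5ccc(F)cc5)ccc4c(=O)c3O)c2)cc1` gives 22800 nM in this assay and stands highest of the three numbers: a 3.6-fold higher number from compound 1 to compound 3 (0.56 log units; beyond the scatter), and a 4.0-fold higher number from compound 2 to compound 3 (0.60 log units; beyond the scatter).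

Compound 4 `CCCc1ccc(C(=O)Nc2cccc(-c3oc4cc(-c5ccc(F)cc5)ccc4c(=O)c3O)c2)cc1` differs from compound 3 by methyl in place of hydrogen on a saturated chain carbon, two bonds along the chain from an aromatic carbon. Within the data shown here, the only steps that touch this part of the molecule are the two that lead into compound 3, both a modest rise in number, but neither extends the chain itself, so the effect of a further carbon on the saturated chain is without precedent here. With the measured steps pointing to a weaker compound once the 4-ethylphenyl is present, compound 4 is expected to sit close to compound 3, with the expected step of a 1.2-fold higher number from compound 3 to compound 4 (0.09 log units; within the scatter) small and not safely beyond the scatter. In this assay compound 4 is estimated at 28000 nM, with a range from 12000 nM to 70000 nM.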

Compound 4, half-maximal inhibitory concentration: 36800 nM
Compound 4: the middle estimate sits 1.3-fold (0.12 log units) below what was measured; the range from low to high includes it.
By their numbers in this assay, from the lowest: compounds 2 and 1 (each within the scatter of the next); then compounds 3 and 4 (each within the scatter of the next).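

In this assay, lengthening the ethyl to propyl at this position leaves compound 4 unseparated from compound 3 (a 1.6-fold higher number from compound 3 to compound 4 (0.21 log units; within the scatter)), so the added methyl on the saturated chain gives no measurable change here. The gap from the other two amides persists with the 4-propylphenyl group (a 6.4-fold higher number from compound 2 to compound 4 (0.80 log units; beyond the scatter)) and with propyl in place of methoxy (a 5.9-fold higher number from compound 1 to compound 4 (0.77 log units; beyond the scatter)), so compounds 3 and 4 both stand apart from compounds 1 and 2. No measurement available here bears on the cause of these steps.

On these data alone, whether a longer chain such as butyl would stay level with compounds 3 and 4 remains open. Also open, as far as these compounds go, is how a branched isopropyl or a carboxylic acid at this position would compare with propyl.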